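The source may hold more compounds than are shown below. What is called first, only, known or untested is meant among the compounds shown, and "the series" means these compounds.

Measured compounds:
compound 1, `O=c1[nH]c(=O)n([C@H]2S[C@H](CO)[C@@H](O)[C@@H]2O)cc1/C=C/Cl`, > 100 ug/mL
compound 2, `Nc1ncnc2c1ncn2[C@@H]1S[C@H](CO)[C@@H](O)[C@@H]1O`, 14.8 ug/mL
compound 3, `CCc1cn([C@@H]2S[C@H](CO)[C@@H](O)[C@@H]2O)c(=O)[nH]c1=O`, > 100 ug/mL

All three were tested in a functional assay on CCRF-HSB-2 cells (Homo sapiens) for antiproliferative activity; on this read-out higher numbers stand for weaker inhibition and lower numbers for stronger inhibition. For compound 1 the reading is a limit of the assay, > 100 ug/mL, not a number. For compound 3 the reading is likewise a limit, > 100 ug/mL. For the measured compounds named here, compound 2 stands apart: in this assay compound 2 gives 14.8 ug/mL, the only numerical value in the set, while the other two sit at the limit of > 100 ug/mL in this assay, at which 2 of the 3 values shown sit.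

The step of interest leads from compound 2 to compound 4, `Nc1ncnc2c1ncn2[C@H]1S[C@H](CO)[C@@H](O)[C@@H]1O`, which is not yet measured. The change is the two compounds have the same atoms and bonds and differ only in configuration as drawn: 1 of 4 stereo elements differ; a stereocentre at a saturated ring carbon is drawn R in compound 2 and S in compound 4. Going by the values given here, no measured pair in this set differs in a comparable way, so there is no measured step to lean on; the expectation rests on compound 2 and its value 14.8 ug/mL alone.

The step of a 5.4-fold higher number from compound 2 to compound 4 (0.73 log units; beyond the scatter) is expected to point toward weaker inhibition, by more than the usual scatter. For compound 4 the estimate in this assay is 80 ug/mL, in a range from 20 ug/mL to 300 ug/mL, with a fair chance that only a limit is reported.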

Compound 4, half-maximal inhibitory concentration: > 100 ug/mL
Compound 4: only a limit was reported (the forecaster's own chance of this, stated with the estimate: 50%); at least 1.2-fold (0.09 log units) between middle value and limit.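

Drawing one stereocentre at a saturated ring carbon as S instead of R gives an at least 6.7-fold higher number from compound 2 to compound 4 (0.82 log units; beyond the scatter) in this assay. For the compounds shown here, this is the first step in the set that can be tied to a single difference, and it shows that configuration at this one carbon is enough to separate a measurable reading from one that is not, with the atoms and bonds left unchanged. Compound 4 now sits at a limit and not at a number, so the step gives only a lower bound on the true change: the limit of > 100 ug/mL in this assay, at which 3 of the 4 values shown sit. The weaker inhibition can be assigned to this stereocentre, and to no change of group: the fact that compounds 2 and 4 differ only in the configuration as drawn.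

How far compound 4 really lies from compound 2 stays open, as does the contribution of the other stereo elements, since the compounds shown vary only this one. They also do not tell whether compound 2 would keep its inhibition with a different group on its core, such as a carboxylic acid or a longer chain.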